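Moving the nitro group: compound 3 awaits its number

A few compounds are considered here, and "the series" means these few. Any claim that something is new, unique, unknown or untested is made for them only; others in the source may bear on it.

compound 1 `CNC(=O)c1cc(Oc2ccc(C(=O)/C=C/c3ccc([N+](=O)[O-])cc3)cc2)ccn1` gives "not determined" (no result reported)
compound 2 `CNC(=O)c1cc(Oc2ccc(/C=C/C(=O)c3ccc([N+](=O)[O-])cc3)cc2)ccn1` gives 54300 nM

In a functional assay on MCF7 cells (Homo sapiens) for cytotoxicity, read by MTT assay, with a stated time of 72 h (on this read-out lower numbers stand for stronger inhibition and higher numbers for weaker inhibition), compound 1 has no single number, so it holds no place on the scale. Only compound 2 has a measured value, 54300 nM. Compound 3 `CNC(=O)c1cc(Oc2ccc(C(=O)/C=C/c3cccc([N+](=O)[O-])c3)cc2)ccn1` has not yet been measured. The structural change is 3-nitrophenyl in place of 4-nitrophenyl on a double-bonded chain carbon bound to a double-bonded chain carbon, which keeps the same atoms but joins them differently. Within the data shown here, no measured step shows what such a change does, so no step beyond the scatter is expected in either direction in this assay. Among the measured compounds shown here, the only number available as an anchor is that of compound 2 at 54300 nM. For compound 3 the expected value is 40000 nM, with an estimated range from 10000 nM to 100000 nM.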

Compound 3, half-maximal inhibitory concentration: > 50000 nM
Compound 3: only a limit was reported (the forecaster's own chance of this, stated with the estimate: 25%); at least 1.2-fold (0.09 log units) between middle value and limit.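

In this assay compound 3 gives > 50000 nM, which is a limit and not a number. Among these compounds, compound 1 has no number, so no step between compound 1 and compound 3 can be read. As far as these compounds go, whether 3-nitrophenyl in place of 4-nitrophenyl changes the cytotoxicity at all stays open.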